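The compounds below may be only part of what the source reports. "The series", "measured", "known", "first", "only" and "open" are said of these compounds alone.

Compound 3 `COc1cc2c(Oc3ccc(NC(=O)N/N=C/c4ccc([N+](=O)[O-])cc4)cc3F)ccnc2cc1OCCCN1CCC(C)CC1` gives the lowest number of the three measured in a functional assay on HT-29 cells (Homo sapiens) for cytotoxicity, read by MTT assay, with a stated time of 72 h (a higher number here means a weaker inhibitor, a lower number a stronger inhibitor), at 230 nM. Compound 1 `COc1cc2c(Oc3ccc(NC(=O)N/N=C/c4ccc(C(F)(F)F)cc4)cc3F)ccnc2cc1OCCCN1CCCC1` gives 810 nM, and compound 2 `COc1cc2c(Oc3ccc(NC(=O)N/N=C/c4ccc(C(F)(F)F)cc4)cc3F)ccnc2cc1OCCCN1CCCCC1` gives 660 nM; both carry trifluoromethyl where compound 3 carries nitro, and both also differ from compound 3 at the saturated amine ring. Compound 4 `COc1cc2c(Oc3ccc(NC(=O)N/N=C/c4ccc(C(F)(F)F)cc4)cc3F)ccnc2cc1OCCCN1CCC(C)CC1` carries trifluoromethyl in place of nitro on an aromatic carbon. Among the measured compounds shown here, no measured step isolates this exchange; the only single-point step, a 1.2-fold lower number from compound 1 to compound 2 (0.09 log units; within the scatter), concerns the amine ring alone. Taking that step as a guide, the amine ring changes little, and the gap between compound 2 and compound 3 would then rest chiefly on the aryl substituent. Compound 4 is therefore expected to give a higher number than compound 3. The expected step is a 2.4-fold higher number from compound 3 to compound 4 (0.38 log units; beyond the scatter). Compound 4 is estimated at 550 nM, with a range from 250 nM to 1300 nM.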

Compound 4, half-maximal inhibitory concentration: 740 nM
Compound 4: the middle estimate sits 1.3-fold (0.13 log units) below what was measured, and the stated range covers the measured number.
By their numbers in this assay, from the lowest: compound 3; then compounds 2, 4 and 1 (each within the scatter of the next).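

In this assay the exchange of nitro for trifluoromethyl, on an aromatic carbon para to a large group, is now isolated and is beyond the scatter (a 3.2-fold higher number from compound 3 to compound 4 (0.51 log units; beyond the scatter)). With trifluoromethyl held, the amine ring shows no separation within the scatter, both for the added ring methyl (a 1.1-fold higher number from compound 2 to compound 4 (0.05 log units; within the scatter)) and for 4-methylpiperidin-1-yl in place of pyrrolidin-1-yl (a 1.1-fold lower number from compound 1 to compound 4 (0.04 log units; within the scatter)). No evidence here accounts for the gap between nitro and trifluoromethyl. Open, going by these compounds, is whether the amine ring stays equally silent with nitro in place, and where a nitrile or a methoxy group at this aromatic carbon would fall.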